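Microsomal stability: methyl in place of chloro on compound 2

The source may hold more compounds than are shown below. What is called first, only, known or untested is meant among the compounds shown, and "the series" means these compounds.

The series shares one core, varied at two places. In an ADME assay on microsomes from liver (Mus musculus) for metabolic stability, read by LC-MS, using NADPH, with stated times of 5 min and 30 min, tested at 1 uM (a higher number here means that more of the compound is left, a lower number that less of the compound is left), compound 1 `O=C(O)c1ccc(-n2cc(C(=O)c3c(Cl)cccc3Cl)c3cccnc32)cc1` gives 100%; compound 3 `O=C(O)c1ccc(-n2cc(C(=O)c3c(Cl)cccc3Cl)c3ccncc32)cc1` gives 100%; compound 2 `O=C(O)c1ccc(-n2cc(C(=O)c3c(Cl)cccc3Cl)c3cccnc32)c(F)c1` gives 92%, the lowest of the three numbers, though a number 8 percentage points lower from compound 1 to compound 2 (within the scatter) and its gap to compound 3 both lie within the scatter. Compound 4 `Cc1cccc(Cl)c1C(=O)c1cn(-c2ccc(C(=O)O)cc2F)c2ncccc12` differs from compound 2 by methyl in place of chloro on an aromatic carbon. Among the measured compounds shown here, no measured step exchanges chloro for methyl; the only measured step, fluoro in place of hydrogen, stayed within the scatter, and all three numbers sit close to full recovery. Compound 4 is therefore expected to show no step beyond the scatter, no change at the digits printed from compound 2 to compound 4 (within the scatter). The value of compound 4 is estimated at 92%, within 75% to 100%.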

Compound 4, percent of the compound remaining in the Mus musculus assay: 93%
The estimate for compound 4 lay 1 percentage points below the measured number, within the range that was stated.
By their numbers in the Mus musculus assay, from the lowest: compounds 2, 4, 1 and 3 (each within the scatter of the next).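

Among the compounds shown here, in the Mus musculus assay, 2,6-dichlorophenyl to 2-chloro-6-methylphenyl gives a number 1 percentage points higher from compound 2 to compound 4 (within the scatter), the first reading of any exchange at this position, and methyl in place of chloro leaves no step beyond the scatter. In a physicochemical assay for solubility, at pH 7.4 (on this read-out higher numbers stand for higher solubility and lower numbers for lower solubility), compound 4 gives 1960000 nM. In the physicochemical assay compound 2 gives > 2000000 nM, a limit and not a number, so the step to compound 4 cannot be read: the limit of > 2000000 nM in the physicochemical assay, at which 1 of the 2 values shown sits.

The compounds shown leave open whether an amine or a trifluoromethyl at this place would hold the number in the Mus musculus assay, and whether the exchange reads the same on the core of compound 3.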